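Swapping fluoro for methoxy on a weak A549 inhibitor

This account rests on a few compounds, and the source may have more. Where it says the series, first, only, none or still open, it means among the compounds named here.

Of the compounds shown here, two have been tested in a functional assay on A549 cells (Homo sapiens) for inhibition, read by MTT assay; on this read-out higher numbers stand for weaker inhibition and lower numbers for stronger inhibition. Compound 1 `CCCCCCCCn1cc(/C=C/C(=O)c2ccc(NC(=O)CN3CCN(c4ccccc4OC)CC3)cc2)nn1` gives 34000 nM in this assay, and compound 2 `CCCCCCCCCCn1cc(/C=C/C(=O)c2ccc(NC(=O)CN3CCN(c4ccccc4F)CC3)cc2)nn1` gives 57000 nM in this assay; both numbers are large, so inhibition is weak, and the two values lie within the usual scatter of each other, so neither can be called the more potent. Compound 3 `CCCCCCCCCCn1cc(/C=C/C(=O)c2ccc(NC(=O)CN3CCN(c4ccccc4OC)CC3)cc2)nn1` has not yet been measured. It is made from compound 2 by a single change: methoxy in place of fluoro on an aromatic carbon. Compound 1 also carries the 2-methoxyphenyl, and its value in this assay does not differ from that of compound 2 beyond the scatter, so no large step is expected here in either direction. The step from compound 2 to compound 3 is estimated as a 1.3-fold lower number from compound 2 to compound 3 (0.10 log units; within the scatter). Compound 3 is therefore expected to give about 45000 nM, with a likely range from 20000 nM to 100000 nM.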

Compound 3, half-maximal inhibitory concentration: 62500 nM
Beside the measured number, compound 3's estimate is 1.4-fold (0.14 log units) below it; measured number inside the range.
By their numbers in this assay, from the lowest: compounds 1, 2 and 3 (each within the scatter of the next).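

In this assay, methoxy in place of fluoro on this aromatic carbon, ortho to a large group, gives a 1.1-fold higher number from compound 2 to compound 3 (0.04 log units; within the scatter), so compound 2 and compound 3 cannot be told apart. The other single change, ethyl in place of hydrogen on a saturated chain carbon, gives a 1.8-fold higher number from compound 1 to compound 3 (0.26 log units; within the scatter), so compound 1 and compound 3 cannot be told apart either, and neither change shows a measurable effect in these compounds. No other measurement is available to shed light on these results.

Going by these compounds, it remains open whether an amine or a carboxylic acid on this aromatic carbon would move the number beyond the scatter. The same question stands for a much longer chain on the aromatic nitrogen of the core.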